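The source may report more compounds than this note shows. Statements on the series, on what has been measured and on what is new or still open speak of the compounds shown alone.

In an ADME assay on microsomes (Rattus norvegicus) for metabolic stability (on this read-out higher numbers stand for a longer-lived compound and lower numbers for a shorter-lived compound), two compounds sharing a core have been measured so far. Compound 1 (`CC(C)C(=O)N1N=CCC1c1ccccc1`) gives 1.33 h on this scale. Compound 2 (`O=C(C1CCN(C(=O)C(F)(F)F)CC1)N1N=CCC1c1ccccc1`) gives 0.483 h and so holds the lower of the two numbers, with a gap to compound 1 that lies beyond the usual scatter of repeated measurements. Compound 3 (`O=C(c1c[nH]nn1)N1CCC(C(=O)N2N=CCC2c2ccccc2)CC1`) keeps everything in compound 2 except one group, with 1H-1,2,3-triazol-4-yl in place of trifluoromethyl on a carbonyl carbon. Going by the values given here, no two measured compounds differ in one place only, and nothing yet shows what this swap does. The estimate therefore starts from compound 2 at 0.483 h and expects no change beyond the scatter in this assay in either direction. The estimated step of a 1.2-fold higher number from compound 2 to compound 3 (0.09 log units; within the scatter) is a slight rise. Compound 3 is expected at 0.6 h with an estimated range from 0.22 h to 1.3 h for its half-life.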

Compound 3, half-life: > 2.75 h
Compound 3 was reported as a limit (the forecaster's own chance of this, stated with the estimate: 5%); middle value at least 4.5-fold (0.66 log units) away from the limit.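

In this assay, the group on the carbonyl carbon whose other neighbour is an amide-type nitrogen in a ring proves to matter: 1H-1,2,3-triazol-4-yl in place of trifluoromethyl gives an at least 5.6-fold higher number from compound 2 to compound 3 (0.75 log units; beyond the scatter). Going by these compounds alone, this is the first pair that differs in one place only, and it shows that half-life can change beyond the usual scatter through this swap alone. From the compounds shown here alone, the reading for compound 3 is a limit and not a number, so the true size of the step remains unknown: the limit of > 2.75 h in this assay, at which 1 of the 3 values shown sits.

The compounds shown do not reveal why half-life rises, or whether the whole ring or only its hydrogen-bond donor goes with the change. A phenyl ring or a 1-methyl-1H-1,2,3-triazol-4-yl group on the same carbonyl carbon would help separate these possibilities.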